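Cytotoxicity notes on adding a methoxy to compound 2

This account rests on a few compounds, and the source may have more. Where it says the series, first, only, none or still open, it means among the compounds named here.

The series notes cover three compounds built on the shared core: compound 1 (`COC(=O)c1c(NCc2ccc(OC)cc2OC)noc1-c1ccc([N+](=O)[O-])cc1`), compound 2 (`COC(=O)c1c(NCc2ccc(OC)cc2)noc1-c1ccc(Cl)cc1Cl`) and compound 3 (`COC(=O)c1c(NCc2ccc(OC)cc2OC)noc1-c1ccc(Cl)cc1Cl`). In an ADME assay on J774.A1 cells (Mus musculus) for cytotoxicity, read by MTT assay, with a stated time of 48 h (on this read-out higher numbers stand for lower toxicity in this test and lower numbers for higher toxicity in this test), compound 1 has the entry "not determined" (no result reported), so it offers no number for comparison. In this assay compound 2 gives 34700 nM. For the measured compounds named here, this is the only number so far, so compound 2 cannot yet be placed high or low against any other compound.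

Compound 3 differs from compound 2 by one change: methoxy in place of hydrogen on an aromatic carbon. Going by the values given here, no pair of measured compounds shows what a change of this kind does in this assay, so the data give no size or direction for it. The working expectation is therefore no shift beyond the usual scatter, in either direction. The expected change is a 1.2-fold lower number from compound 2 to compound 3 (0.06 log units; within the scatter). For compound 3 the estimated value is 30000 nM, with an expected range from 12000 nM to 75000 nM.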

Compound 3, half-maximal cytotoxic concentration: 32200 nM
Beside the measured number, compound 3's estimate is 1.1-fold (0.03 log units) below it, within the range that was stated.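

In this assay, for the compounds shown here, placing methoxy on the aromatic carbon that is ortho to a large group and meta to a methoxy group gives a 1.1-fold lower number from compound 2 to compound 3 (0.03 log units; within the scatter) and thereby supplies the first readable step for this kind of change. With the rest of compound 2 held constant, the entering group, with its one hydrogen-bond acceptor and no net charge, leaves the read-out within the scatter, so this single pair shows no sensitivity to methoxy at this position in this test. No supporting measurement bears on this result, and the pair offers no explanation for it.

Compound 1 carries no number, so any step involving it cannot be read, and the series still gives no measured effect of its other aryl substitution on this read-out. Going by these compounds, it remains open whether an amine, a carboxylic acid or a longer chain such as ethoxy at this same position would shift the number beyond the scatter, and whether methoxy would behave the same way at another position on this ring.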